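The source may report more compounds than this note shows. Statements on the series, on what has been measured and on what is new or still open speak of the compounds shown alone.

Working notes on the series.

The shared core of compound 1 `O=c1c([C@@H]2C[C@H](c3ccccc3)ON2c2ccccc2)coc2ccc(F)cc12` carries a fluoro on the fused aromatic ring; in a functional assay on THP-1 cells (Homo sapiens) for inhibition, read by sulforhodamine B assay, with a stated time of 48 h (on this read-out lower numbers stand for stronger inhibition and higher numbers for weaker inhibition), compound 1 gives 54700 nM. Among the two numbers recorded so far, compound 1 has the highest number, and its nearest neighbour is compound 2 `O=c1c([C@@H]2C[C@H](c3ccccc3)ON2c2ccccc2)coc2cc(Cl)c(Cl)cc12`, with two chloro groups on the same ring, which in this assay gives 38000 nM; the gap between compound 1 and compound 2 sits within the scatter of repeated measurements, so no order between them can be read. Compound 3 `Cc1ccc2occ([C@@H]3[C@H]4C(=O)N(c5ccccc5)C(=O)[C@H]4ON3c3ccccc3)c(=O)c2c1`, with a different ring arrangement on the core and a methyl on the fused aromatic ring, gives only a limit in this assay, > 60000 nM; it is the limit of the assay, not a number, as shown by the limit of > 60000 nM in this assay, at which 1 of the 3 values shown sits.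

Compound 4 `O=c1c([C@@H]2C[C@H](c3ccccc3)ON2c2ccccc2)coc2ccccc12` has not yet been measured in this assay. Relative to compound 1 it differs by hydrogen in place of fluoro on an aromatic carbon. Within the data shown here, no measured step between compounds differing in one place is available, so the size of this change can only be guessed; nothing among the measured compounds points to a move beyond the scatter in either direction. The step from compound 1 to compound 4 is expected to be a 1.0-fold higher number from compound 1 to compound 4 (0.00 log units; within the scatter), that is, essentially no change. Compound 4 is therefore estimated at 55000 nM, with a range from 22000 nM to 140000 nM, and a fair chance that the assay returns only a limit.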

Compound 4, half-maximal inhibitory concentration: > 60000 nM
Compound 4 ended at the assay's limit; the forecaster's own chance of this, stated with the estimate: 40%; middle value at least 1.0-fold (0.03 log units) away from the limit.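

In this assay, among these compounds, the first step in one place, hydrogen in place of fluoro on an aromatic carbon, reads an at least 1.0-fold higher number from compound 1 to compound 4 (0.04 log units; that floor lies within the scatter). Compound 4 gives only a limit of the assay, so this step is a floor and not a size: it fits anything from no change to a large one, and the fluoro at this position can be called neither needed nor dispensable. The limit now also holds for a compound with the core of compound 1, and not only for compound 3 with its different ring arrangement: the limit of > 60000 nM in this assay, at which 2 of the 4 values shown sit.

On these data alone, how far the true value of compound 4 lies from the limit stays open, and with it the real size of the step. Also open, as far as these compounds go, is whether a methoxy, an amine or a carboxylic acid on this same aromatic carbon would give a number clearly apart from that of compound 1 on the core of compound 1.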